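Antiproliferative screen: a methyl added to a triazole aryl group

The compounds below may be only part of what the source reports. "The series", "measured", "known", "first", "only" and "open" are said of these compounds alone.

Measured compounds:
Compound 1, `N#CC1=C(N)Oc2c(c3nc4ccccc4nc3c3ccccc23)C12C(=O)N(Cc1cnnn1-c1cc(Cl)ccc1Cl)c1ccccc12`: in a functional assay on MCF7 cells (Homo sapiens) for antiproliferative activity, read by MTT assay, with a stated time of 48 h (on this read-out lower numbers stand for stronger inhibition and higher numbers for weaker inhibition), compound 1 gives > 50000 nM, which is a limit of the assay rather than a number.
Compound 2, `N#CC1=C(N)Oc2c(c3nc4ccccc4nc3c3ccccc23)C12C(=O)N(Cc1cnnn1-c1ccc(Cl)c(Cl)c1)c1ccccc12`: in this assay compound 2 gives > 50000 nM, again a limit.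
Compound 3, `N#CC1=C(N)Oc2c(N)cc3nc4ccccc4nc3c2C12C(=O)N(Cc1cnnn1-c1ccc(Cl)cc1)c1ccccc12`: in this assay compound 3 gives > 50000 nM, also a limit.

Compound 3 therefore stands at the same limit as every other compound shown; all three sit at the limit of > 50000 nM in this assay, at which 3 of the 3 values shown sit, so none can be ranked against another.

Compound 4, `Cc1ccc(Cl)cc1-n1nncc1CN1C(=O)C2(C(C#N)=C(N)Oc3c(N)cc4nc5ccccc5nc4c32)c2ccccc21`, differs from compound 3 by one change: 5-chloro-2-methylphenyl in place of 4-chlorophenyl on an aromatic nitrogen.

Among the measured compounds shown here, the only measured step, a step that the two limits leave unreadable from compound 1 to compound 2, cannot be read because both ends are limits, and it concerns different chlorine positions rather than a methyl. No readable step bears on the change from compound 3 to compound 4, so the expectation rests on compound 3 alone, whose value > 50000 nM is a limit. The estimated step that the limit leaves unreadable from compound 3 to compound 4 is expected to be none beyond the scatter. Compound 4 is estimated at 60000 nM in this assay, in a range from 20000 nM to 200000 nM, most likely reported again as a limit.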

Compound 4, half-maximal inhibitory concentration: 43500 nM
The estimate for compound 4 lay 1.4-fold (0.14 log units) above the measured number, and the stated range covers the measured number.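

In this assay, among the compounds shown here, compound 4 gives 43500 nM, so this position on the aromatic nitrogen can carry a group that yields a readable number, something none of the earlier compounds showed. Going by these compounds, replacing 4-chlorophenyl with 5-chloro-2-methylphenyl gives an at least 1.1-fold lower number from compound 3 to compound 4 (0.06 log units; that floor lies within the scatter), so this floor alone does not establish a real gain, and the true size of the step stays unknown. With only one measured number, the compounds still cannot be ranked against one another: the limit of > 50000 nM in this assay, at which 3 of the 4 values shown sit.

The new group differs from the old one in both its added methyl and its chlorine position, so the step cannot be assigned to either alone. On these data alone, whether a plain 2-methylphenyl, or an amine or a carboxylic acid on this phenyl ring, would give a clearly lower number remains open.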